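From Ethyl to Phenyl on the Sulfur

The source may hold more compounds than are shown below. What is called first, only, known or untested is meant among the compounds shown, and "the series" means these compounds.

In a functional assay for inhibition, with Rattus norvegicus as the target (a higher number here means that more compound is needed for the effect, a lower number that less compound is needed), compound 3 `CCSC[C@H](CC1CCCCC1)NCc1ccc(C(=O)N[C@@H](CCSC)C(=O)O)c(-c2ccccc2C)c1` gives 4.4 nM, the lowest number measured here. Compound 1 `CSCC[C@H](NC(=O)c1ccc(CNCCC2CCCCC2)cc1-c1ccccc1C)C(=O)O` gives 200 nM. Compound 2 `CSCC[C@H](NC(=O)c1ccc(CN[C@H](C)CC2CCCCC2)cc1-c1ccccc1C)C(=O)O` gives only a limit of the assay, > 1000 nM.

Compound 4 `CSCC[C@H](NC(=O)c1ccc(CN[C@H](CSc2ccccc2)CC2CCCCC2)cc1-c1ccccc1C)C(=O)O` differs from compound 3 by phenyl in place of ethyl on a sulfur. Within the data shown here, no measured step makes this exact swap. The closest evidence concerns the same side chain: adding (ethylsulfanyl)methyl gave a 45-fold lower number from compound 1 to compound 3 (1.66 log units; beyond the scatter), a large step, whereas adding methyl gave an at least 5.0-fold higher number from compound 1 to compound 2 (0.69 log units; beyond the scatter). Compound 4 keeps the sulfur, so the number is expected to stay close to that of compound 3, with no step beyond the scatter. The expected change is a 1.1-fold lower number from compound 3 to compound 4 (0.04 log units; within the scatter). For compound 4, the estimated value is 4 nM, within an expected range of 1 nM to 20 nM.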

Compound 4, half-maximal effective concentration: 12 nM
Compound 4: middle estimate off by 3.0-fold (0.48 log units), on the low side; the range from low to high includes it.
By their numbers in this assay, from the lowest: compound 3; then compound 4; then compound 1. At a limit, above all of these: compound 2.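

Replacing ethyl with phenyl on this sulfur is not a neutral swap: there is a 2.7-fold higher number from compound 3 to compound 4 (0.44 log units; beyond the scatter). Even so, the side chain carrying the phenyl ring keeps much of the advantage over the unbranched chain, with a 17-fold lower number from compound 1 to compound 4 (1.22 log units; beyond the scatter). Compound 2 has only a limit of the assay, so the comparison with it is a bound: an at least 83-fold lower number from compound 2 to compound 4 (1.92 log units; beyond the scatter).

Going by these compounds, it remains open whether a propyl or benzyl group on the sulfur would give a number closer to that of compound 3 or compound 4. The compounds shown also cannot tell whether the sulfur itself matters, as an oxygen in its place would test.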